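A Methyl Group on the Carboxymethylamino Chain

This account rests on a few compounds, and the source may have more. Where it says the series, first, only, none or still open, it means among the compounds named here.

In a functional assay on K562 cells (Homo sapiens) for cytotoxicity, read by trypan blue exclusion, with a stated time of 96 h (on this read-out higher numbers stand for weaker inhibition and lower numbers for stronger inhibition), compound 1 `COc1cc(OC)c(/C=C/S(=O)(=O)Nc2ccc(OC)c([N+](=O)[O-])c2)c(OC)c1` gives 1000 nM, while compound 2 `COc1cc(OC)c(/C=C/S(=O)(=O)Nc2ccc(OC)c(NCC(=O)O)c2)c(OC)c1` gives 20 nM, the lower of the two numbers. Compound 3 `COc1cc(OC)c(/C=C/S(=O)(=O)Nc2ccc(OC)c(NC(C)C(=O)O)c2)c(OC)c1` differs from compound 2 by methyl in place of hydrogen on a saturated chain carbon bound to a carbonyl carbon and a nitrogen on an aromatic ring, which turns carboxymethyl into 1-carboxyethyl. Among the compounds with values here, only one measured step bears on this change, a 50-fold lower number from compound 1 to compound 2 (1.70 log units; beyond the scatter). That step put the chain in place and did not alter it, so it sets no size for an added methyl. The expected step is a 1.5-fold higher number from compound 2 to compound 3 (0.18 log units; within the scatter), not beyond the scatter. For compound 3 the estimated value is 30 nM, with an expected range from 10 nM to 120 nM.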

Compound 3, half-maximal inhibitory concentration: 8 nM
Beside the measured number, compound 3's estimate is 3.8-fold (0.57 log units) above it; the whole stated range lies above it.
By their numbers in this assay, from the lowest: compound 3; then compound 2; then compound 1.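

In this assay this saturated chain carbon, bound to a carbonyl carbon and a nitrogen on an aromatic ring, does not need to keep both hydrogens: methyl in place of hydrogen gives a 2.5-fold lower number from compound 2 to compound 3 (0.40 log units; beyond the scatter), a modest step. Measured against the nitro compound, the (1-carboxyethyl)amino group gives a 130-fold lower number from compound 1 to compound 3 (2.10 log units; beyond the scatter), the lowest number of the three. Nothing shown here gives a cause for the methyl step. Still open, as far as these compounds go, is whether ethyl or isopropyl on that carbon would lower the number further, and whether a methyl ester could stand in place of the carboxylic acid.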